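Oxan-2-yl Carbonyl in Place of Propanoyl on the Core

The source may report more compounds than this note shows. Statements on the series, on what has been measured and on what is new or still open speak of the compounds shown alone.

The three measured compounds share the core of compound 1 `O=C1NCCc2nc(C#Cc3cccc(F)c3)sc21`, which in an assay on HEK293 cells for positive allosteric modulation of metabotropic glutamate receptor 5 (Homo sapiens), read by FLIPR, with a stated time of 1 h (a lower number here means that less compound is needed, a higher number that more compound is needed for the effect), gives 290 nM. Compound 3 `O=C(C1CC(F)(F)C1)N1CCc2nc(C#Cc3cccc(F)c3)sc2C1`, an amide carrying a ring on its carbonyl carbon, gives 2.5 nM in this assay. Compound 2 `CCC(=O)N1CCc2nc(C#Cc3ccccc3)sc2C1` stands apart: in this assay compound 2 gives > 10000 nM, which is a limit of the assay and not a number. Among the measured compounds shown here, it is the one value that sits at the limit of > 10000 nM in this assay, at which 1 of the 3 values shown sits.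

Compound 4 `O=C(C1CCCCO1)N1CCc2nc(C#Cc3ccccc3)sc2C1` is built from compound 2 by oxan-2-yl in place of ethyl on a carbonyl carbon. For the measured compounds named here, no measured pair differs in a single place, so the size of this step has to be estimated. Compound 3 shows that an amide with a ring on the carbonyl carbon can reach 2.5 nM, but compound 3 also carries a fluorine on the phenyl ring that compound 4 lacks, so it gives only a loose guide. The step from compound 2 to compound 4 is expected to lower the concentration needed, by an amount of an at least 6.6-fold lower number from compound 2 to compound 4 (0.82 log units; beyond the scatter). Compound 4 is estimated at 1500 nM, with a range from 150 nM to 10000 nM, and there remains a fair chance that this assay again returns only a limit.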

Compound 4, half-maximal effective concentration: 320 nM
Estimate against measurement, compound 4: 4.7-fold (0.67 log units) above; measured number inside the range.
By their numbers in this assay, from the lowest: compound 3; then compounds 1 and 4 (each within the scatter of the next). At a limit, above all of these: compound 2.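

Oxan-2-yl in place of ethyl on a carbonyl carbon is the first change at this position that can be read on its own, and in this assay it gives an at least 31-fold lower number from compound 2 to compound 4 (1.49 log units; beyond the scatter). Going by these compounds, compound 2 gives a limit of the assay and not a number, so this step is a bound and its true size stays unknown because of where compound 2 stands: the limit of > 10000 nM in this assay, at which 1 of the 4 values shown sits. The earlier compounds shown here offered no pair differing in one place, whereas compound 4 shows that, with the phenyl ring of compound 2 left unchanged, the change on the carbonyl carbon alone is enough to bring a limit down to a measured value.

The compounds shown do not separate the contribution of the ring from that of its oxygen, and a cyclohexyl group on the same carbonyl carbon would be needed to tell the two apart. On these data alone, it also remains open whether a fluorine on the phenyl ring of compound 4 would change its value, and why the oxan-2-yl group has the effect it does.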